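The compounds below may be only part of what the source reports. "The series", "measured", "known", "first", "only" and "open" are said of these compounds alone.

Measured so far:
- compound 1 `CCNS(=O)(=O)c1cccc(-c2ccc(OCC)cc2)c1`: 46%
- compound 2 `CCOc1ccc(-c2cccc(C(=O)OCCOCCOC)c2)cc1`: 43%

In an assay on COS-7 cells for inhibition of patatin-like phospholipase domain-containing protein 2 (Mus musculus), tested at 200 uM (on this read-out lower numbers stand for less inhibition and higher numbers for more inhibition at the one concentration tested (going by the name of the read-out)), compound 1 gives 46% and compound 2 gives 43%; the two numbers lie within the scatter of each other, so neither can be set apart from the other. Compound 2 is therefore one of two closely matched numbers, not a high or a low point of the series.

Compound 3 `CCNC(=O)c1cccc(-c2ccc(OCC)cc2)c1` is the next compound to go into this assay. It keeps the shared core of compound 2 and changes only the group on the carbonyl carbon: ethylamino in place of 2-(2-methoxyethoxy)ethoxy on a carbonyl carbon. For the measured compounds named here, no pair of measured compounds isolates this exchange, so nothing measured sets its size. Compound 1 also carries an ethylamino group and gives a number within the scatter of compound 2, which gives no reason to expect a large move.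

The step from compound 2 to compound 3 in this assay is expected to be small, a number 2 percentage points higher from compound 2 to compound 3 (within the scatter), within the scatter. Compound 3 is estimated at 45%, between 25% and 65%.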

Compound 3, a percentage reported as inhibition, at one concentration (the size of the read-out at that concentration, not a potency): 62%
For compound 3 the middle estimate is 17 percentage points below the measured one, and the stated range covers the measured number.
By their numbers in this assay, from the lowest: compounds 2 and 1 (each within the scatter of the next); then compound 3.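

In this assay, for the compounds shown here, ethylamino in place of 2-(2-methoxyethoxy)ethoxy on a carbonyl carbon gives a number 19 percentage points higher from compound 2 to compound 3 (beyond the scatter), so the group on this carbonyl carbon can move the number beyond the scatter, something no earlier pair could isolate. Ethylcarbamoyl in place of ethylsulfamoyl on an aromatic carbon gives a number 16 percentage points higher from compound 1 to compound 3 (beyond the scatter), so with the ethylamino group present in both compounds, the exchange of the sulfonyl-based group for the carbonyl-based one also registers beyond the scatter. Nothing available accounts for either step.

The exchange from compound 2 to compound 3 alters chain length and the amide hydrogen together, so these two changes stay unseparated. A dimethylamino group, a propylamino group or a carboxylic acid on the same carbonyl carbon would show which of them tracks with the number.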